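This account rests on a few compounds, and the source may have more. Where it says the series, first, only, none or still open, it means among the compounds named here.

In an ADME assay on MRC5 cells (Homo sapiens) for cytotoxicity, read by MTT assay, with a stated time of 72 h (a higher number here means that more compound is tolerated, a lower number that less compound is tolerated), compound 1 `OC[C@H]1O[C@@H](n2cc(F)c3c(-c4ccc[nH]4)ncnc32)[C@H](O)[C@@H]1O` gives 44500 nM. Compound 2 `CCCCCCCCCCCCCCCCCCOP(=O)(O)OC[C@H]1O[C@@H](n2ccc3c(-c4ccccc4)ncnc32)[C@H](O)[C@@H]1O` gives > 50000 nM, which is a limit of the assay and not a number. The measured picture is therefore thin: the limit of > 50000 nM in this assay, at which 1 of the 2 values shown sits. Compound 3 `CCCCCCCCCCCCCCCCCCOP(=O)(O)OC[C@H]1O[C@@H](n2ccc3c(-c4ccco4)ncnc32)[C@H](O)[C@@H]1O` keeps everything in compound 2 except one group, with furan-2-yl in place of phenyl on an aromatic carbon. Within the data shown here, no measured pair of compounds differs in one place only, so no direct precedent exists for this change. Among the measured compounds shown here, the only guide is compound 2 with its limit of > 50000 nM, and on that basis no shift beyond the usual scatter is expected in this assay. The expected step, a number no higher from compound 2 to compound 3 (the limit leaves the size open), is accordingly an estimate of no real change, and the assay may again report only a limit. Compound 3 is estimated at 50000 nM, with an expected range from 22000 nM to 100000 nM.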

Compound 3, half-maximal cytotoxic concentration: 45300 nM
Estimate against measurement, compound 3: 1.1-fold (0.04 log units) above, within the range that was stated.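

In this assay, furan-2-yl in place of phenyl on an aromatic carbon gives an at least 1.1-fold lower number from compound 2 to compound 3 (0.04 log units; that floor lies within the scatter), the first step read at this position. With this five-membered aromatic ring in place, compound 3 gives a measured number, 45300 nM. The change does not move the read-out beyond the scatter as far as the smallest size the step can have is able to show. The true size of the step remains unknown, as it rests on a limit of the assay held by compound 2: the limit of > 50000 nM in this assay, at which 1 of the 3 values shown sits.

The compounds shown leave open whether an amine or a carboxylic acid at this position would give a step beyond the scatter. They also leave open what a shorter chain on the phosphate would do to the number.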